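The source may report more compounds than this note shows. Statements on the series, on what has been measured and on what is new or still open speak of the compounds shown alone.

Working notes on the series. Compound 2 (`Fc1ccc(N2CCN(Cc3ccn4c(CC5CC5)nnc4c3C(F)(F)F)CC2)c(Cl)c1`) carries a 2-chloro-4-fluorophenyl group on the shared core. In a functional assay on HEK293 cells for agonist activity at metabotropic glutamate receptor 8 (Homo sapiens), read by a luciferase reporter and cAMP accumulation (a lower number here means that less compound is needed, a higher number that more compound is needed for the effect), compound 2 gives only a limit, > 10000 nM. Compound 1 (`Fc1ccc(N2CCN(Cc3cc(C(F)(F)F)cn4c(CC5CC5)nnc34)CC2)c(F)c1`), with the trifluoromethyl placed differently on the core, also reaches only a limit in this assay, > 10000 nM. Compound 3 (`Fc1ccc(C2CCN(Cc3ccn4c(CC5CC5)nnc4c3C(F)(F)F)CC2)c(F)c1`) likewise gives a limit in this assay, > 10000 nM. Going by the values given here, no step between measured compounds can be stated, because every value shown sits at the limit of > 10000 nM in this assay, at which 3 of the 3 values shown sit, so nothing is known about how any change on the aryl group moves the read-out.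

Compound 4 (`Fc1ccc(N2CCN(Cc3ccn4c(CC5CC5)nnc4c3C(F)(F)F)CC2)c(F)c1`) is compound 2 with fluoro in place of chloro on an aromatic carbon; cut one bond further out, 2-chloro-4-fluorophenyl becomes 2,4-difluorophenyl. With all three measured values at a limit, the step in this assay is expected to be a step that the limit leaves unreadable from compound 2 to compound 4, none beyond the scatter, and the result is most likely again only a limit. Compound 4 is estimated at 20000 nM, with a range from 8000 nM to 100000 nM.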

Compound 4, half-maximal effective concentration: > 8000 nM
Compound 4: only a limit was reported; the forecaster's own chance of this, stated with the estimate: 85%; the middle value does not contradict the limit.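

In this assay compound 4 gives only a limit (> 8000 nM). Going by these compounds alone, compound 2 is also only a limit, so no step between compound 2 and compound 4 can be read. The compounds shown leave open whether fluoro in place of chloro moves the read-out at all, and what concentration any of them needs for the effect.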